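A few compounds are considered here, and "the series" means these few. Any claim that something is new, unique, unknown or untested is made for them only; others in the source may bear on it.

Of the compounds shown here, three have been measured in a functional assay on SW-620 cells (Homo sapiens) for antiproliferative activity, read by MTT assay, with a stated time of 72 h (on this read-out higher numbers stand for weaker inhibition and lower numbers for stronger inhibition), and none of them gave a number. Compound 1 `CCCCCCc1cc2cn(Cc3cn(-c4ccccc4F)nn3)c(=O)nc2o1` stands at > 100000 nM, which is a limit of this assay rather than a measured value. Compound 2 `CCCCCc1ccc(C#Cc2c(-c3ccc(CCCCC)cc3)oc3nc(=O)n(Cc4cn(-c5ccc(Cl)cc5)nn4)cc23)cc1` likewise returns > 100000 nM, again a limit. Compound 3 `CCCCCCC#Cc1c(CCCCCC)oc2nc(=O)n(Cc3cn(-c4ccc(F)cc4)nn3)cc12`, the starting point here, comes out at > 100000 nM, also a limit. Where compound 3 stands among the numbers shown is therefore simple: it shares (the limit of > 100000 nM in this assay, at which 3 of the 3 values shown sit), and nothing separates it from the other two.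

Compound 4 `CCCCCCC#Cc1c(CCCCCC)oc2nc(=O)n(Cc3cn(Cc4ccccc4)nn3)cc12` is not yet measured. It differs from compound 3 in one place: benzyl in place of 4-fluorophenyl on an aromatic nitrogen. For the measured compounds named here, no step between two measured compounds is available to show how a change at this nitrogen moves the read-out, so the expectation rests on the limits alone. Every measured compound sits at the limit of > 100000 nM in this assay, at which 3 of the 3 values shown sit, and the most likely outcome is that compound 4 is also reported only as a limit. The expected step is a number no higher from compound 3 to compound 4 (the limit leaves the size open), nothing beyond the usual scatter. Compound 4 is expected to give about 100000 nM in this assay, within the range 30000 nM to 300000 nM.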

Compound 4, half-maximal inhibitory concentration: 32600 nM
Compound 4: the middle estimate sits 3.1-fold (0.49 log units) above what was measured; measured number inside the range.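

For the compounds shown here, putting benzyl in place of 4-fluorophenyl on the aromatic nitrogen gives an at least 3.0-fold lower number from compound 3 to compound 4 (0.48 log units; beyond the scatter) in this assay, the first sign that a change at this position can bring a compound in this set to a measurable number. As far as these compounds go, the true size of this step stays unknown: compound 3 has a limit and not a number, so the step can only be read as a minimum. Compound 4 is the only compound here with a number, and the others remain at a limit: the limit of > 100000 nM in this assay, at which 3 of the 4 values shown sit.

The swap changes two things at once, adding a carbon between the nitrogen and the six-membered ring and removing the fluorine, and it stays open which of these matters, as neither plain phenyl nor 4-fluorobenzyl is shown at this nitrogen. Also open, from the compounds shown here alone, is whether a longer link such as 2-phenylethyl, or a side chain ending in an amine, would lower the number further, and whether benzyl would have the same effect with other chains on the shared core.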